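The source may report more compounds than this note shows. Statements on the series, on what has been measured and on what is new or still open speak of the compounds shown alone.

In a functional assay on TOV21G cells (Homo sapiens) for antiproliferative activity, read by sulforhodamine B assay, with a stated time of 3 days (a lower number here means a stronger inhibitor of growth, a higher number a weaker inhibitor of growth), compound 1 `CCc1cc(F)ccc1-c1nc(-c2ccc3[nH]c(=O)oc3c2)cs1` gives only a limit, > 50000 nM. Compound 2 `Cc1cc(F)ccc1-c1nc(-c2ccc3c(c2)CC(=O)N3)cs1` also gives only a limit, > 50000 nM. Going by the values given here, the series therefore stands without a measured number so far: the limit of > 50000 nM in this assay, at which 2 of the 2 values shown sit. Among the compounds with values here, no step between measured compounds is available to guide the next reading.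

The next compound is compound 3 `NCCOCc1cc(F)ccc1-c1nc(-c2ccc3[nH]c(=O)oc3c2)cs1`, which carries 2-aminoethoxy in place of methyl on a saturated chain carbon bound to an aromatic carbon. Compound 1 is known only through its limit of > 50000 nM, so any measurable change would lie toward stronger growth inhibition. A moderate step in that direction, beyond the scatter, is expected, though a reading that again reaches the limit remains quite possible. The expected step is an at least 6.2-fold lower number from compound 1 to compound 3 (0.79 log units; beyond the scatter). For compound 3 the estimated value is 8000 nM, with an expected range of 1000 nM to 50000 nM.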

Compound 3, concentration for 50% growth inhibition: > 50000 nM
Compound 3: a limit, no number; the forecaster's own chance of this, stated with the estimate: 40%; middle value at least 6.2-fold (0.79 log units) from the limit.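

Going by these compounds alone, compound 3, like compound 1, is known only through a limit, so no step between the two can be read. The compounds shown leave open whether any change at this place on the shared core gives a measurable number in this assay: the limit of > 50000 nM in this assay, at which 3 of the 3 values shown sit.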